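The source may hold more compounds than are shown below. What is called first, only, known or untested is meant among the compounds shown, and "the series" means these compounds.

The series rests on the shared core of compound 1 `Cc1ccc(NC(=O)C(=O)NC(c2nc(C)c(CCO)s2)C2CCCCN2)cc1F`. In an ADME assay on TZM-b1 cells (Homo sapiens) for cytotoxicity, read by XTT assay, with a stated time of 3 days (a lower number here means that less compound is tolerated, a higher number that more compound is tolerated), compound 1 gives only a limit of the assay, > 85000 nM. Compound 2 `Cc1ccc(NC(=O)C(=O)NC(c2nc(C)c(CCO)s2)C2CCCCN2)c(F)c1` carries 2-fluoro-4-methylphenyl in place of 3-fluoro-4-methylphenyl on an amide-type nitrogen. In this assay compound 2 also gives a limit, > 78800 nM. The step that the two limits leave unreadable from compound 1 to compound 2 cannot be read, since the limit of > 78800 nM in this assay, at which 1 of the 2 values shown sits, and the limit of > 85000 nM in this assay, at which 1 of the 2 values shown sits, both sit at a limit and no number separates them. For the measured compounds named here, compound 2 thus stands at a limit, and the one further value shown is a limit as well.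

Compound 3 `Cc1ccc(NC(=O)C(=O)NC(c2nc(C)c(CO)s2)C2CCCCN2)c(F)c1` differs from compound 2 by hydroxy in place of hydroxymethyl on a saturated chain carbon bound to an aromatic carbon. Going by the values given here, no measured step bears on this change, and the single step from compound 1 to compound 2 is unreadable. The numbers therefore give no direction, and the expected step that the limit leaves unreadable from compound 2 to compound 3 in this assay is one within the scatter, most likely ending again at a limit. Compound 3 is accordingly estimated at 80000 nM in this assay, with a range from 40000 nM to 160000 nM.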

Compound 3, half-maximal cytotoxic concentration: > 88000 nM
Compound 3: no number, only a limit (the forecaster's own chance of this, stated with the estimate: 85%); middle value at least 1.1-fold (0.04 log units) away from the limit.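

In this assay compound 3 gives only a limit of the assay, > 88000 nM. For the compounds shown here, compound 2 also stands at a limit, so no step from compound 2 to compound 3 can be read. The compounds shown leave open where the half-maximal cytotoxic concentrations of compound 1, compound 2 and compound 3 lie, and whether either change shifts them in this assay.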